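The compounds below may be only part of what the source reports. "The series", "measured", "known", "first", "only" and "open" are said of these compounds alone.

In an ADME assay on microsomes from liver (Homo sapiens) for metabolic stability (a higher number here means faster removal of the compound, a lower number slower removal), compound 3 `COc1cccc([C@H](c2cc3cc(C#N)ccc3nc2OC)[C@@](O)(CCN(C)C)c2cc(SC)nc(SC)c2)c1F` gives 15 uL/min, the second highest of the three numbers shown. Compound 2 `COc1cc([C@](O)(CCN(C)C)[C@@H](c2cc3cc(C#N)ccc3nc2OC)c2cccc(OC)c2F)cc(SC)n1` gives 16 uL/min, within the scatter of compound 3, and compound 1 `COc1cc([C@](O)(CCN(C)C)[C@@H](c2cc3cc(C#N)ccc3nc2OC)c2cccc(C)c2F)cc(OC(F)F)n1` gives 0.6 uL/min, far below both. Among the measured compounds shown here, the single measured step, a 1.1-fold lower number from compound 2 to compound 3 (0.03 log units; within the scatter), shows that exchange leaves this assay essentially unchanged.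

Compound 4 `COc1nc2ccc(C#N)cc2cc1[C@@H](c1cccc(C)c1F)[C@@](O)(CCN(C)C)c1cc(SC)nc(SC)c1` differs from compound 3 by methyl in place of methoxy on an aromatic carbon. For the measured compounds named here, no measured pair isolates this change: compound 1 carries the methyl group and compound 2 the methoxy group, but they also differ elsewhere, so the wide gap between their values cannot be credited to the methyl alone. Compound 4 is nevertheless expected to give a lower number than compound 3, a 2.1-fold lower number from compound 3 to compound 4 (0.33 log units; beyond the scatter), with broad uncertainty. The estimate for compound 4 is 7 uL/min, between 2 uL/min and 18 uL/min.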

Compound 4, intrinsic clearance in a liver preparation (reported as CLH), per the amount of preparation that the assay uses: 9.2 uL/min
Compound 4: the middle estimate sits 1.3-fold (0.12 log units) below what was measured, within the range that was stated.
By their numbers in this assay, from the lowest: compound 1; then compounds 4, 3 and 2 (each within the scatter of the next).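

In this assay, the exchange at this position can now be read alone: a 1.6-fold lower number from compound 3 to compound 4 (0.21 log units; within the scatter), so methyl in place of methoxy on the fluorinated ring makes no difference beyond the scatter. With the 2-fluoro-3-methylphenyl group held constant, the large step of a 15-fold higher number from compound 1 to compound 4 (1.19 log units; beyond the scatter) comes with the exchange of the other aromatic group, so the methyl does not carry the low number of compound 1. Which substituent on that exchanged group accounts for the step stays open, as does what a chloro or an ethyl group in place of the methyl would give. Nothing shown gives a reason for either step.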